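Changing the sulfonamide aryl group between compound 2 and compound 3

This account rests on a few compounds, and the source may have more. Where it says the series, first, only, none or still open, it means among the compounds named here.

In a functional assay on T47D cells (Homo sapiens) for cytotoxicity, read by sulforhodamine B assay, with a stated time of 48 h (a lower number here means a stronger inhibitor, a higher number a weaker inhibitor), compound 2 `O=C(/C=C\Nc1ccc(S(=O)(=O)Nc2ccccn2)cc1)c1cc2ccccc2oc1=O` gives 37600 nM, the lowest of the two numbers at hand. Compound 1 `CN(C)/C=C/C(=O)c1cc2ccccc2oc1=O` gives 147000 nM, a gap beyond the scatter. Compound 3 `O=C(/C=C\Nc1ccc(S(=O)(=O)Nc2ccc3cn[nH]c3c2)cc1)c1cc2ccccc2oc1=O` differs from compound 2 by 1H-indazol-6-yl in place of pyridin-2-yl on a sulfonamide nitrogen. Among the compounds with values here, no measured pair shows this change, so only a small step is expected, if any, leaning toward a lower number. Compound 3 is therefore expected to give 25000 nM, within 8000 nM to 80000 nM. The expected step is a 1.5-fold lower number from compound 2 to compound 3 (0.18 log units; within the scatter).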

Compound 3, half-maximal inhibitory concentration: 96500 nM
Estimate against measurement, compound 3: 3.9-fold (0.59 log units) below; measured number above the stated range.
By their numbers in this assay, from the lowest: compound 2; then compounds 3 and 1 (each within the scatter of the next).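

In this assay, the group on the sulfonamide nitrogen proves able to shift the number: 1H-indazol-6-yl in place of pyridin-2-yl gives a 2.6-fold higher number from compound 2 to compound 3 (0.41 log units; beyond the scatter). This single change adds heavy atoms, a second ring and a hydrogen-bond donor together, and one step cannot separate these differences. Nothing at hand explains the rise.

On these data alone, whether a plain phenyl group would give a lower or higher number than pyridin-2-yl remains open. So does the effect of an amine or a carboxylic acid on the pyridine ring.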